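The compounds below may be only part of what the source reports. "The series", "measured", "known", "first", "only" and "open" are said of these compounds alone.

The study measured cytotoxicity in an ADME assay on HELF cells (Homo sapiens) for cytotoxicity, with a stated time of 3 days; on this read-out higher numbers stand for lower toxicity in this test and lower numbers for higher toxicity in this test. Compound 1 `CC(C)CNC(=O)[C@H](C)NC(=O)[C@@]1(Cc2ccccc2)CCN1C(=O)OCc1ccccc1` does not reach a number in that test: in this assay compound 1 gives > 100000 nM, which is a limit of the assay rather than a measured value. Compound 2 `C[C@H](NC(=O)[C@]1(Cc2ccccc2)CCN1C(=O)OCc1ccc([N+](=O)[O-])cc1)C(N)=O` likewise gives in this assay only the limit > 100000 nM. Compound 1 thus stands exactly where every value shown stands, at the limit of > 100000 nM in this assay, at which 2 of the 2 values shown sit. Compound 3 `C[C@H](NC(=O)[C@@]1(Cc2ccccc2)CCN1C(=O)OCc1ccccc1)C(=O)NCc1ccccc1` differs from compound 1 in a single place: phenyl in place of isopropyl on a saturated chain carbon bound to an amide-type nitrogen. For the measured compounds named here, no pair of measured compounds differing in just one place is available, so no measured step can be quoted for this change, and both measured values are limits that give no number to compare. The step from compound 1 to compound 3 is therefore expected to be none beyond the scatter, a number no higher from compound 1 to compound 3 (the limit leaves the size open). Compound 3 is expected to give in this assay about 100000 nM, with a range from 50000 nM to 200000 nM, and most likely again only a limit.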

Compound 3, half-maximal cytotoxic concentration: 42000 nM
For compound 3 the middle estimate is 2.4-fold (0.38 log units) above the measured one, outside the stated range (below it).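

For the compounds shown here, the change at this place is the first to move the read-out off the limit of the assay: in this assay, phenyl in place of isopropyl on a saturated chain carbon bound to an amide-type nitrogen gives an at least 2.3-fold lower number from compound 1 to compound 3 (0.37 log units; beyond the scatter), a step beyond the usual scatter. Going by these compounds alone, compound 3, at 42000 nM, therefore provides the first actual number and shows that this position, where isobutylcarbamoyl becomes benzylcarbamoyl, can affect the outcome of this assay towards higher toxicity in this test, which the earlier compounds could not show. Compound 3 is the only compound shown that gives such a number, while the others remain at the limit: the limit of > 100000 nM in this assay, at which 2 of the 3 values shown sit.

The true size of the step remains open, since it rests on one pair of compounds and one end of that pair is only a limit, and nothing shown says why the change has this effect. On these data alone, it is also open how an amine, a carboxylic acid or a longer alkyl chain at this place would read in this assay, and whether the same change would lower the number on a compound with a different carbamate, such as the nitrobenzyl one of compound 2.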